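A few compounds are considered here, and "the series" means these few. Any claim that something is new, unique, unknown or untested is made for them only; others in the source may bear on it.

Measured in an ADME assay on MRC5 cells (Homo sapiens) for inhibition, with a stated time of 72 h; a higher number here means that more compound is needed for the effect, a lower number that less compound is needed:
Compound 1 `COc1cccc(OC)c1C(=O)Nc1c[nH]nc1C(=O)N[C@H]1CC[C@H](OC)CC1` gives 31000 nM.
Compound 2 `COc1cccc(OC)c1C(=O)Nc1c[nH]nc1C(=O)NCCN1CCCC1` reaches only the assay limit, > 50000 nM.
Compound 3 `COc1cccc(OC)c1C(=O)Nc1c[nH]nc1C(=O)NC1CCCCCC1` gives 42000 nM.

Compound 1 stands lowest of the two numbers shown, though the step of a 1.4-fold higher number from compound 1 to compound 3 (0.13 log units; within the scatter) lies within the scatter. For compound 2 a limit is all that is known (the limit of > 50000 nM in this assay, at which 1 of the 3 values shown sits). Compound 4 `COc1ccccc1C(=O)Nc1c[nH]nc1C(=O)N[C@H]1CC[C@H](OC)CC1` is not yet measured. It differs from compound 1 by hydrogen in place of methoxy on an aromatic carbon. Among the compounds with values here, none of the measured steps touches this place; an at least 1.6-fold higher number from compound 1 to compound 2 (0.20 log units; that floor lies within the scatter) and an at least 1.1-fold lower number from compound 2 to compound 3 (0.07 log units; that floor lies within the scatter) vary the amide-type nitrogen substituent, and none of them moves beyond the scatter. Within the data shown here, no measured step therefore bears on the change to compound 4, and no shift beyond the scatter in this assay is expected. Compound 4 is estimated at 31000 nM, range 14000 nM to 70000 nM. The expected step is no change at the digits printed from compound 1 to compound 4 (within the scatter).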

Compound 4, half-maximal effective concentration: 1500 nM
Beside the measured number, compound 4's estimate is 21-fold (1.32 log units) above it; measured number below the stated range.
By their numbers in this assay, from the lowest: compound 4; then compounds 1 and 3 (each within the scatter of the next). At a limit, above all of these: compound 2.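

In this assay, hydrogen in place of methoxy on an aromatic carbon gives a 21-fold lower number from compound 1 to compound 4 (1.32 log units; beyond the scatter) and so stands as the only step shown that lies beyond the scatter. This place on the ring therefore matters in a way the amide-type nitrogen changes did not reveal, and compound 4 still keeps its other methoxy group. Nothing at hand accounts for the size of this step.

Open, as far as these compounds go, is whether a fluorine, a chlorine, a methyl or an ethoxy group at this aromatic carbon would behave like hydrogen or like methoxy. Also open, from the compounds shown here alone, are the effect of removing the remaining methoxy group and whether the change carries over to the cycloheptyl amide.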